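Compound 3 to compound 4: fluoro to methoxy

A few compounds are considered here, and "the series" means these few. Any claim that something is new, unique, unknown or untested is made for them only; others in the source may bear on it.

- compound 1 `O=C(O)c1csc(-n2nc(-c3ccccc3)c3c2CCCC3)n1` gives 290 mL/min/kg
- compound 2 `O=C(O)c1csc(-n2nc(-c3ccccc3)c3ccc(O)cc32)n1` gives 522 mL/min/kg
- compound 3 `O=C(O)c1csc(-n2nc(-c3ccc(F)cc3)c3ccccc32)n1` gives 278 mL/min/kg

In an ADME assay (liver) for metabolic stability, with Liver microsome (Rattus norvegicus) as the target, using microsomes (a higher number here means faster removal of the compound, a lower number slower removal), the three compounds lie within the scatter of one another, so compound 3 stands level with compound 1 and compound 2. Compound 4 `COc1ccc(-c2nn(-c3nc(C(=O)O)cs3)c3ccccc23)cc1` carries methoxy in place of fluoro on an aromatic carbon, para to a large group methoxy in place of fluoro on an aromatic carbon and otherwise matches compound 3. For the measured compounds named here, no measured pair isolates this change, so its size is not known directly. A small upward move is expected, estimated as a 1.3-fold higher number from compound 3 to compound 4 (0.11 log units; within the scatter) and probably within the scatter, though the direction is only a weak call. The expectation rests on compound 3 at 278 mL/min/kg having both other values within the scatter of it. For compound 4 the estimate is 360 mL/min/kg (expected range 190 mL/min/kg to 650 mL/min/kg).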

Compound 4, clearance: 618 mL/min/kg
Estimate against measurement, compound 4: 1.7-fold (0.23 log units) below; measured number inside the range.
By their numbers in this assay, from the lowest: compounds 3, 1, 2 and 4 (each within the scatter of the next, the first and the last beyond it).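

For the compounds shown here, the first comparison in one place in this assay gives a 2.2-fold higher number from compound 3 to compound 4 (0.35 log units; beyond the scatter), so the group on this aromatic carbon, para to a large group, registers in this read-out, and methoxy in place of fluoro is a modest step beyond the scatter. Nothing available bears on the reason for this step. The compounds shown leave open whether the step is specific to methoxy or would also appear with an amine or a longer chain such as ethoxy at this position. On these data alone, whether the same change would carry over to the core of compound 1 also remains open.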